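The source may report more compounds than this note shows. Statements on the series, on what has been measured and on what is new or still open speak of the compounds shown alone.

Among the measured compounds shown here, compound 1 `Cc1ccc(-c2cn(CCC3(O)NC(=O)C(OCc4ccccc4)=C3OCc3ccccc3)nn2)cc1` is the only one of the three compounds for which a functional assay on HCT-116 cells (Homo sapiens) for antiproliferative activity, read by MTT assay, with a stated time of 24 h (a lower number here means a stronger inhibitor, a higher number a weaker inhibitor), returns a number: in that assay compound 1 gives 74300 nM. Compound 2 `CCCc1cn(CCC2(O)C(OCc3ccccc3)=C(OCc3ccccc3)C(=O)N2CCC)nn1` is reported in this assay only as a limit, > 100000 nM. Compound 3 `CC(C)(C)c1ccc(-c2cn(C/C=C3\OC(=O)C(OCc4ccccc4)=C3OCc3ccccc3)nn2)cc1` likewise reaches only a limit in this assay, > 100000 nM. With two of the three results sitting at the limit of > 100000 nM in this assay, at which 2 of the 3 values shown sit, compound 1 alone offers a point to step from. Compound 4 `O=C1NC(O)(CCn2cc(-c3ccccc3)nn2)C(OCc2ccccc2)=C1OCc1ccccc1` differs from compound 1 by hydrogen in place of methyl on an aromatic carbon. For the measured compounds named here, no measured pair shows the effect of this change, so the step is expected to be a 1.2-fold higher number from compound 1 to compound 4 (0.08 log units; within the scatter), which stays within the usual scatter. Compound 4 is expected to give about 90000 nM in this assay, between 40000 nM and 200000 nM.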

Compound 4, half-maximal inhibitory concentration: 53400 nM
The estimate for compound 4 lay 1.7-fold (0.23 log units) above the measured number, within the range that was stated.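

In this assay the change from 4-methylphenyl to phenyl gives a 1.4-fold lower number from compound 1 to compound 4 (0.14 log units; within the scatter) and so shows that the methyl on this aromatic carbon can be lost without a change that stands out from the scatter. Among the compounds shown here, this is the first step between measured compounds that can be read, since it joins two numbers rather than a limit. No measurement shown here offers a reason for this step. On these data alone, whether an amine, a carboxylic acid or a longer chain in place of the methyl would move the number beyond the scatter stays open.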